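Swapping the Ring on the Carbonyl Carbon of Compound 1

A few compounds are considered here, and "the series" means these few. Any claim that something is new, unique, unknown or untested is made for them only; others in the source may bear on it.

Among the measured compounds shown here, compound 1 `CC1CCN(C(=O)c2c(N)sc(-c3ccc(Cl)cc3)c2-c2ccc(Cl)cc2)CC1` gives 1750 nM in a functional assay on A549 cells (Homo sapiens) for inhibition, read by sulforhodamine B assay, with a stated time of 72 h (on this read-out lower numbers stand for stronger inhibition and higher numbers for weaker inhibition), the lowest of the two numbers measured so far. Compound 2 `CC(C)CNC(=O)c1c(N)sc(-c2ccc(Cl)cc2)c1-c1ccc(Cl)cc1` gives 21000 nM in this assay. Compound 3 `Nc1sc(-c2ccc(Cl)cc2)c(-c2ccc(Cl)cc2)c1C(=O)N1CCNCC1` differs from compound 1 by piperazin-1-yl in place of 4-methylpiperidin-1-yl on a carbonyl carbon. For the measured compounds named here, the one measured step that alters the same place is a 12-fold higher number from compound 1 to compound 2 (1.08 log units; beyond the scatter), where isobutylamino stood in place of 4-methylpiperidin-1-yl. Compound 3 keeps a six-membered ring there, so a smaller step is expected, most likely toward a higher number. Compound 3 is therefore estimated at 3500 nM, between 1200 nM and 10000 nM, a step of a 2.0-fold higher number from compound 1 to compound 3 (0.30 log units; within the scatter).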

Compound 3, half-maximal inhibitory concentration: 1020 nM
Compound 3: middle estimate off by 3.4-fold (0.54 log units), on the high side; measured number below the stated range.
By their numbers in this assay, from the lowest: compounds 3 and 1 (each within the scatter of the next); then compound 2.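

Exchanging 4-methylpiperidin-1-yl for piperazin-1-yl on this carbonyl carbon brings in a hydrogen-bond donor and acceptor, yet the numbers stay within the scatter, with a 1.7-fold lower number from compound 1 to compound 3 (0.23 log units; within the scatter) as the step. Both six-membered rings stand clearly apart from isobutylamino, as a 21-fold lower number from compound 2 to compound 3 (1.31 log units; beyond the scatter) shows alongside the earlier step. Nothing available explains that gap between the rings and the open chain.

Piperidin-1-yl without the methyl, or morpholin-4-yl, would test the ring atoms one at a time. Going by these compounds, how other open-chain amines, such as diethylamino, compare remains open.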